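This account rests on a few compounds, and the source may have more. Where it says the series, first, only, none or still open, it means among the compounds named here.

Compound 2 `CN1CCN(c2ccc(Nc3ncc(Cl)c(NCc4ccccc4)n3)nc2)CC1` gives the lower of the two numbers measured here. In a functional assay on MDA-MB-231 cells (Homo sapiens) for inhibition, read by CCK-8 assay, with a stated time of 48 h (on this read-out higher numbers stand for weaker inhibition of growth and lower numbers for stronger inhibition of growth), compound 2 gives 24800 nM, while compound 1 `Cc1ccccc1Nc1nc(Nc2cc(Cl)ccn2)ncc1Cl` gives 52400 nM, a gap beyond the usual scatter. Compound 3 `COc1cccc(Nc2nc(Nc3ccc(N4CCN(C)CC4)cn3)ncc2Cl)c1` has not yet been measured. Among the measured compounds shown here, its single change from compound 2 is 3-methoxyphenyl in place of benzyl on a nitrogen on an aromatic ring. For the measured compounds named here, no measured pair shows this change on its own, so its effect is unknown; a modest move toward stronger inhibition of growth is expected, close to the edge of the scatter. Compound 3 is therefore estimated at 15000 nM, with a range from 5000 nM to 45000 nM. The expected step is a 1.7-fold lower number from compound 2 to compound 3 (0.22 log units; within the scatter).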

Compound 3, concentration for 50% growth inhibition: 8510 nM
Compound 3: the middle estimate sits 1.8-fold (0.25 log units) above what was measured, within the range that was stated.
By their numbers in this assay, from the lowest: compound 3; then compound 2; then compound 1.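

Putting 3-methoxyphenyl in place of benzyl on this nitrogen takes the number in this assay down, with a 2.9-fold lower number from compound 2 to compound 3 (0.46 log units; beyond the scatter) as the step. Among the compounds shown here, this is the first single-place comparison, and it shows that the group on this nitrogen can shift growth inhibition, though only modestly. No measurement shown here explains the shift.

The compounds shown leave open whether the step comes from losing the carbon link of benzyl or from adding the methoxy group. A plain phenyl on the same nitrogen would separate the two.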